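The compounds below may be only part of what the source reports. "The series", "measured", "known", "first", "only" and "open" are said of these compounds alone.

Of the compounds shown here, three of one shared core have been measured in a physicochemical assay for acid dissociation, using potentiometric titration. Compound 1 `CC(=O)/C(C)=N/OCc1cc(=O)oc2ccc(Cl)cc12` gives 5.4 in this assay. Compound 2 `CC(=O)/C(C)=N/OCc1cc(=O)oc2cc(C)cc(C)c12` gives 5.5, and compound 3 `CC(=O)/C(C)=N/OCc1cc(=O)oc2c(C)c(C)ccc12` gives 5.5. The number for compound 1 sits at the low end of the three, yet the numbers for compound 2 and compound 3 both lie within the usual scatter of it, so no real separation between the three can be claimed.

Compound 4 `CC(=O)/C(C)=N/OCc1cc(=O)oc2ccc(C)cc12` has not yet been measured in this assay. It differs from compound 1 in one place: methyl in place of chloro on an aromatic carbon, a methyl in place of chloro on an aromatic carbon. Among the compounds with values here, no measured pair shows what this exchange does to the readout. Since compound 2, which carries methyl groups on the same core, returns 5.5 and compound 3, which also carries methyl groups, returns 5.5, a step no larger than the scatter is expected here. For compound 4 the estimate is 5.5, with a range from 5.2 to 5.8. The expected step is a number 0.10 log units higher from compound 1 to compound 4 (within the scatter).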

Compound 4, acid dissociation constant: 5.7
The estimate for compound 4 lay 0.20 log units below the measured number; low and high end bracket the measured number.
By their numbers in this assay, from the lowest: compounds 1, 2, 3 and 4 (each within the scatter of the next).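

Within the data shown here, compound 1 and compound 4 are the first pair here that differs in one place, so the effect of a single exchange can now be read directly. In this assay, putting methyl in place of chloro on this aromatic carbon, meta to a fused ring and para to a fused ring, gives a number 0.30 log units higher from compound 1 to compound 4 (within the scatter) for this pair, so the exchange cannot be told apart from repeat-to-repeat variation. No other measurement shown bears on this result.

Going by these compounds, whether an amine, a carboxylic acid or a longer chain on this same carbon would give a step beyond the scatter remains open. Compound 2 and compound 3 each differ from compound 1 in more than one place, so how chloro and methyl compare on other aromatic carbons of the shared core is also unresolved.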